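A Trifluoromethyl Swap on a Sulfonamide Inhibitor

The compounds below may be only part of what the source reports. "The series", "measured", "known", "first", "only" and "open" are said of these compounds alone.

Of the compounds shown here, three have been measured in an assay on isolated protein for inhibition of Nicotinamide phosphoribosyltransferase (Homo sapiens), read by WST assay, with stated times of 60 min, 5 min and 30 min, in the presence of a further agent that is not named here; a higher number here means a weaker inhibitor, a lower number a stronger inhibitor. Compound 1 `O=C(/C=C/c1cccnc1)NCCCCc1ccc(S(=O)(=O)Nc2ccccc2)cc1` gives 17.8 nM, compound 2 `O=C(/C=C/c1cccnc1)NCCCCCCCc1cccc(S(=O)(=O)Nc2ccccc2)c1` gives 31.3 nM, and compound 3 `Cc1ccc(NS(=O)(=O)c2cccc(CCCCCCNC(=O)/C=C/c3cccnc3)c2)cc1` gives 9.78 nM. Compound 3 has the lowest of the three numbers, but its gap to compound 1 lies within the usual scatter of repeated measurements, so those two cannot be ordered; only compound 2 sits clearly higher than compound 3.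

Compound 4 `O=C(/C=C/c1cccnc1)NCCCCCCc1cccc(S(=O)(=O)Nc2ccc(C(F)(F)F)cc2)c1` has not yet been measured. It differs from compound 3 in a single place: trifluoromethyl in place of methyl on an aromatic carbon. Among the measured compounds shown here, no two measured compounds differ in only one place, so there is no measured step to lean on. Exchanging one group with no net charge for another of the same kind on an aromatic carbon is expected to move the number only a little, and the estimated step of a 1.1-fold higher number from compound 3 to compound 4 (0.05 log units; within the scatter) is expected to stay within the scatter, in no particular direction. Compound 4 is therefore expected to give about 11 nM in this assay, with a range from 4 nM to 30 nM.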

Compound 4, half-maximal inhibitory concentration: 24.5 nM
Estimate against measurement, compound 4: 2.2-fold (0.35 log units) below, and the stated range covers the measured number.
By their numbers in this assay, from the lowest: compounds 3, 1, 4 and 2 (each within the scatter of the next, the first and the last beyond it).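

In this assay, among the compounds shown here, replacing 4-methylphenyl with 4-(trifluoromethyl)phenyl gives a 2.5-fold higher number from compound 3 to compound 4 (0.40 log units; beyond the scatter) as the first step in this set that changes only one place, showing that this position responds to the group it carries. The effect is modest, but it is beyond the scatter, and it appears although the swap leaves the counts of hydrogen-bond donors and acceptors and the net charge unchanged. Nothing available here explains why the number rises.

For the compounds shown here, with only one step at this position, there is no trend to read, and whether a chlorine, a methoxy group or an amine in the same place would fall nearer compound 3 or compound 4 remains open. It is also unknown whether the same swap would have a similar effect with the shorter chain of compound 1 or the longer chain of compound 2.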